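Anilide variation on the thioacetamide quinazoline series

The source may report more compounds than this note shows. Statements on the series, on what has been measured and on what is new or still open speak of the compounds shown alone.

Compound 3 `O=C(CSc1nc(Nc2ccccc2)c2ccccc2n1)Nc1ccc([N+](=O)[O-])cc1` in a functional assay on NCI-H1975 cells (Homo sapiens) for inhibition, read by MTT assay, with a stated time of 72 h (a higher number here means a weaker inhibitor, a lower number a stronger inhibitor), gives 13000 nM, and compound 1 `CCc1cccc(NC(=O)CSc2nc(Nc3ccccc3)c3ccccc3n2)c1` gives 12000 nM, while compound 2 `O=C(CSc1nc(Nc2ccccc2)c2ccccc2n1)Nc1ccc(Cl)cc1` gives 8040 nM; all three lie within the scatter of one another. Compound 4 `O=C(CSc1nc(Nc2ccccc2)c2ccccc2n1)Nc1ccc(F)c(Cl)c1` carries 3-chloro-4-fluorophenyl in place of 4-nitrophenyl on an amide-type nitrogen. Going by the values given here, the steps that bear on this aryl swap are a 1.5-fold lower number from compound 1 to compound 2 (0.17 log units; within the scatter), a 1.1-fold higher number from compound 1 to compound 3 (0.03 log units; within the scatter) and a 1.6-fold higher number from compound 2 to compound 3 (0.21 log units; within the scatter), each within the scatter, so no change beyond the scatter is expected for this assay from a further aryl replacement of this kind. Compound 4 is therefore expected near 10000 nM, with a range from 4500 nM to 22000 nM. The expected step of a 1.3-fold lower number from compound 3 to compound 4 (0.11 log units; within the scatter) is estimated to stay within the scatter.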

Compound 4, half-maximal inhibitory concentration: 9390 nM
The estimate for compound 4 lay 1.1-fold (0.03 log units) above the measured number; measured number inside the range.
By their numbers in this assay, from the lowest: compounds 2, 4, 1 and 3 (each within the scatter of the next).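

In this assay, 3-chloro-4-fluorophenyl on the amide-type nitrogen stays within the scatter of all three earlier anilides (a 1.4-fold lower number from compound 3 to compound 4 (0.14 log units; within the scatter); a 1.2-fold higher number from compound 2 to compound 4 (0.07 log units; within the scatter); a 1.3-fold lower number from compound 1 to compound 4 (0.11 log units; within the scatter)). A ring carrying both chloro and fluoro therefore separates no better from 4-nitrophenyl, 4-chlorophenyl or 3-ethylphenyl than those three do from one another. No available evidence bears on this result.

From the compounds shown here alone, whether an amine, a carboxylic acid or a longer chain on this ring would move the number beyond the scatter remains open. Also open, going by these compounds, is whether a saturated ring in place of the phenyl would do so.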